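The source may report more compounds than this note shows. Statements on the series, on what has been measured and on what is new or still open speak of the compounds shown alone.

Measured so far in a functional assay on the whole organism for inhibition, with Lepidium sativum as the target, tested at 100 ppm; on this read-out higher numbers stand for more inhibition of growth at the one concentration tested and lower numbers for less inhibition of growth:
compound 1 `CCOC(=O)C(Cc1ccccc1)ON1C(=O)c2ccccc2C1=O`: 70%
compound 2 `CCCC(C)ON1C(=O)c2ccccc2C1=O`: 56%
compound 3 `CCOC(=O)C(CC)ON1C(=O)c2ccccc2C1=O`: 94%

Compound 3 stands highest of the three in this assay; compound 1 lies nearest and compound 2 furthest, both beyond the scatter. Compound 4 `CCOC(=O)C(C)ON1C(=O)c2ccccc2C1=O` is not yet measured. It differs from compound 3 by hydrogen in place of methyl on a saturated chain carbon, two bonds along the chain from a carbonyl carbon and an oxygen on an unsaturated carbon. Within the data shown here, one measured step bears on the same carbon: a number 24 percentage points higher from compound 1 to compound 3 (beyond the scatter), where the smaller group went with stronger inhibition. Compound 2 differs from compound 3 in more than one place and shows only its own value. Ethyl to methyl is a far smaller change than phenyl to methyl, and compound 3 already stands close to full inhibition. For compound 4 the expected step is therefore a number 6 percentage points lower from compound 3 to compound 4 (within the scatter). Compound 4 is estimated at 88% in this assay, with a range of 68% to 100%.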

Compound 4, percent growth inhibition at one concentration: 100%
The estimate for compound 4 lay 12 percentage points below the measured number; the measured number falls inside the stated range.
By their numbers in this assay, from the lowest: compound 2; then compound 1; then compounds 3 and 4 (each within the scatter of the next).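

In this assay, ethyl to methyl on this carbon moves the number only slightly (a number 6 percentage points higher from compound 3 to compound 4 (within the scatter)), so the two small chains cannot be told apart here. The phenyl comparison now has a second member (a number 30 percentage points higher from compound 1 to compound 4 (beyond the scatter)), and both small chains stand clear of compound 1. Among these compounds, the first single change at the ester itself, ethoxycarbonyl in place of propyl, gives the largest step (a number 44 percentage points higher from compound 2 to compound 4 (beyond the scatter)). No measurement on hand explains these steps. Open, from the compounds shown here alone, is whether a carboxylic acid or an amide in place of ethoxycarbonyl keeps this inhibition, and how a longer chain than ethyl behaves on this carbon.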